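The source may hold more compounds than are shown below. What is called first, only, known or untested is meant among the compounds shown, and "the series" means these compounds.

Compounds measured in an assay on CHO cells for displacement of a labelled ligand from adenosine receptor A3 (Homo sapiens), read by scintillation counting, with a stated time of 45 min, tested at 1 uM, in the presence of a further agent that is not named here; on this read-out higher numbers stand for more inhibition at the one concentration tested (going by the name of the read-out) and lower numbers for less inhibition:
compound 1 `CCCn1c(=O)[nH]c2nc(-c3ccc(S(=O)(=O)N4CCN(C)CC4)cc3)[nH]c2c1=O`, 7%;
compound 2 `CCCn1c(=O)[nH]c2nc(-c3ccc(S(=O)(=O)N4CCN(c5ccc(Br)cc5)CC4)cc3)[nH]c2c1=O`, 29%;
compound 3 `CCCn1c(=O)[nH]c2nc(-c3ccc(S(=O)(=O)N4CCN(c5ccccc5)CC4)cc3)[nH]c2c1=O`, 27%.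

Compound 1 stands lowest of the three in this assay, with compound 3 nearest and compound 2 furthest from it. Compound 4 `CCCn1c(=O)[nH]c2nc(-c3ccc(S(=O)(=O)N4CCN(c5ccc(Cl)cc5F)CC4)cc3)[nH]c2c1=O` differs from compound 1 in one place: 4-chloro-2-fluorophenyl in place of methyl on an amine nitrogen in a ring. Going by the values given here, two measured steps bear on this change, both replacing the same methyl with an aryl group: a number 22 percentage points higher from compound 1 to compound 2 (beyond the scatter) and a number 20 percentage points higher from compound 1 to compound 3 (beyond the scatter). Between the two aryl compounds, a number 2 percentage points lower from compound 2 to compound 3 (within the scatter), so a halogen on that ring made no difference beyond the scatter. A modest upward step is therefore expected for compound 4 in this assay, namely a number 20 percentage points higher from compound 1 to compound 4 (beyond the scatter). Compound 4 is estimated at 27%, with a range from 13% to 41%.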

Compound 4, a percentage reported as inhibition, at one concentration (the size of the read-out at that concentration, not a potency): 14%
Estimate against measurement, compound 4: 13 percentage points above, and the stated range covers the measured number.
By their numbers in this assay, from the lowest: compounds 1 and 4 (each within the scatter of the next); then compounds 3 and 2 (each within the scatter of the next).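

In this assay, an aryl group on this amine nitrogen does not always bring a step beyond the scatter: 4-chloro-2-fluorophenyl in place of methyl gives a number 7 percentage points higher from compound 1 to compound 4 (within the scatter). Against the other aryl groups, the same group gives a number 13 percentage points lower from compound 3 to compound 4 (beyond the scatter) and a number 15 percentage points lower from compound 2 to compound 4 (beyond the scatter), so the substituents on this ring can count here, although removing bromo did not. Nothing measured here accounts for this result. From the compounds shown here alone, what 2-fluorophenyl or 4-chlorophenyl alone would give on this nitrogen remains open. So does the outcome with a benzyl group there.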